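The source may report more compounds than this note shows. Statements on the series, on what has been measured and on what is new or still open speak of the compounds shown alone.

Compound 3 `CCn1cc(C(=O)N2N=C(c3cc4ccccc4o3)CC2c2ccccc2O)c(=O)c2ccc(C)nc21` is known in an ADME assay on Vero cells (Chlorocebus sabaeus) for cytotoxicity, read by MTT assay, with a stated time of 72 h (a lower number here means a stronger inhibitor, a higher number a weaker inhibitor), only as a limit: compound 3 gives > 157000 nM. The two other values recorded are limits as well. Compound 1 `CN(C)c1ccc(C2CC(c3cc4ccccc4o3)=NN2C(=O)c2ccncc2)cc1` gives > 210000 nM in this assay, a limit. Compound 2 `O=C(c1ccncc1)N1N=C(c2cc3ccccc3o2)CC1c1ccc(O)cc1` gives > 200000 nM, again a limit. Among the compounds with values here, the single step between measured compounds, a step that the two limits leave unreadable from compound 1 to compound 2, is thus unreadable, as the limit of > 210000 nM in this assay, at which 1 of the 3 values shown sits, and the limit of > 200000 nM in this assay, at which 1 of the 3 values shown sits, together show, and the limit of > 157000 nM in this assay, at which 1 of the 3 values shown sits, places compound 3 in the same situation, with no numbers below any limit.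

The change from compound 3 to compound 4 `CCn1cc(C(=O)N2N=C(c3cc4ccccc4o3)CC2c2ccc(Cl)cc2)c(=O)c2ccc(C)nc21` is 4-chlorophenyl in place of 2-hydroxyphenyl on a saturated ring carbon. Within the data shown here, no measured step touches that carbon; the only known step concerns a group on an aromatic carbon, and its size could not be read. The chemist therefore expects no step beyond the scatter in this assay, and a value that is most likely again a limit. Compound 4 is expected near 200000 nM, within 60000 nM to 500000 nM, an expected step that the limit leaves unreadable from compound 3 to compound 4.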

Compound 4, half-maximal inhibitory concentration: > 160000 nM
Compound 4: no number, only a limit; the forecaster's own chance of this, stated with the estimate: 80%; the middle value is on the limit's open side.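

In this assay compound 4 gives > 160000 nM, a limit. Compound 3 is also known only as a limit, so no step can be read between compound 3 and compound 4. The compounds shown leave open what any of them would actually read in this assay, since all four values are limits.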